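Adding a third fluoro to compound 3

A few compounds are considered here, and "the series" means these few. Any claim that something is new, unique, unknown or untested is made for them only; others in the source may bear on it.

Measured so far in a functional assay with Homo sapiens as the target (on this read-out higher numbers stand for weaker inhibition and lower numbers for stronger inhibition), are these compounds:
- Compound 1 `CC(C)[C@H](NC(=O)COc1cccc2ccccc12)C(=O)N[C@@H](CC(=O)O)C(=O)COc1ccccc1C(F)(F)F` gives 17300 nM
- Compound 2 `CC(C)[C@H](NC(=O)COc1cccc2ccccc12)C(=O)N[C@@H](CC(=O)O)C(=O)COc1ccc(F)cc1` gives 14300 nM
- Compound 3 `CC(C)[C@H](NC(=O)COc1cccc2ccccc12)C(=O)N[C@@H](CC(=O)O)C(=O)COc1ccc(F)cc1F` gives 17600 nM

Compound 3 gives 17600 nM in this assay and so sits level with compound 1 and compound 2, all three lying within the usual scatter of one another. The next compound is compound 4 `CC(C)[C@H](NC(=O)COc1cccc2ccccc12)C(=O)N[C@@H](CC(=O)O)C(=O)COc1cc(F)c(F)cc1F`, which has fluoro in place of hydrogen on an aromatic carbon and so turns 2,4-difluorophenyl into 2,4,5-trifluorophenyl. The new fluoro is ortho to a fluoro group, para to a fluoro group and meta to a large group.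

Among the measured compounds shown here, the closest precedent is a 1.2-fold higher number from compound 2 to compound 3 (0.09 log units; within the scatter) for the same kind of swap. Two wider swaps on this group also moved little, namely a 1.2-fold lower number from compound 1 to compound 2 (0.08 log units; within the scatter) and a 1.0-fold higher number from compound 1 to compound 3 (0.01 log units; within the scatter) in the same read-out. For the measured compounds named here, only three compounds stand behind this, and none carries a fluoro at the new place, so a surprise remains possible. Even so, no step beyond the scatter is expected. The expected step is a 1.1-fold lower number from compound 3 to compound 4 (0.04 log units; within the scatter) on this estimate. Compound 4 is therefore expected at 16000 nM with a likely range of 9000 nM to 28000 nM in this assay when it is measured.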

Compound 4, half-maximal inhibitory concentration: 16700 nM
Beside the measured number, compound 4's estimate is 1.0-fold (0.02 log units) below it; low and high end bracket the measured number.
By their numbers in this assay, from the lowest: compounds 2, 4, 1 and 3 (each within the scatter of the next).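

In this assay, placing a fluoro on the aromatic carbon ortho to a fluoro group, para to a fluoro group and meta to a large group gives a 1.1-fold lower number from compound 3 to compound 4 (0.02 log units; within the scatter) and does not shift the number beyond the scatter, which shows that a fluoro at this previously empty place leaves the read-out level. The new 2,4,5-trifluorophenyl group also stays level with the earlier groups on the oxygen, with a 1.2-fold higher number from compound 2 to compound 4 (0.07 log units; within the scatter) and a 1.0-fold lower number from compound 1 to compound 4 (0.02 log units; within the scatter), so all four compounds now read alike and none goes against this flat picture. Nothing available here bears on why the number stays flat.

The compounds shown carry only fluoro and trifluoromethyl on this ring, so it remains open whether an amine, a methoxy or a carboxylic acid at the same place would also leave the number level. On these data alone, it is equally open whether any change to this group can move this assay beyond the scatter at all, or whether such a step would have to come from elsewhere on the shared core.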